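A few compounds are considered here, and "the series" means these few. Any claim that something is new, unique, unknown or untested is made for them only; others in the source may bear on it.

Series notes. In a functional assay for inhibition, with Rattus norvegicus as the target (on this read-out lower numbers stand for stronger inhibition and higher numbers for weaker inhibition), compound 2 `CC(C)(C)/N=c1\c(O)c(O)\c1=N/Cc1ccc(C#N)c(Cl)c1` gives 1100 nM. Compound 1 `CCc1cc(C/N=c2\c(O)c(O)\c2=N/C(C)(C)C)ccc1C#N` differs from it by ethyl in place of chloro on an aromatic carbon and in this assay compound 1 gives 6100 nM, a step of a 5.5-fold higher number from compound 2 to compound 1 (0.74 log units; beyond the scatter). Compound 3 `CCC(C)(C)/N=c1\c(O)c(O)\c1=N/Cc1ccc(C#N)cc1Cl` stands on another core than compound 2; the difference between the two cores is not broken down here. In this assay compound 3 gives 130 nM, the lowest of the three numbers. Compound 4 `CCc1cc(C#N)ccc1C/N=c1\c(O)c(O)\c1=N/C(C)(C)CC` is yet to be measured and differs from compound 3 by ethyl in place of chloro on an aromatic carbon. This is the same kind of change as from compound 2 to compound 1, but not the same: there the place was ortho to a cyano group and meta to a large group, here it is ortho to a large group and meta to a cyano group. For the measured compounds named here, the step from compound 3 to compound 4 is expected to be a 4.6-fold higher number from compound 3 to compound 4 (0.66 log units; beyond the scatter), resting on the measured step of a 5.5-fold higher number from compound 2 to compound 1 (0.74 log units; beyond the scatter), the only earlier instance of this change, with the differing surroundings leaving the size uncertain. Compound 4 is therefore estimated at 600 nM in this assay, between 150 nM and 2500 nM.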

Compound 4, half-maximal inhibitory concentration: 110 nM
Beside the measured number, compound 4's estimate is 5.5-fold (0.74 log units) above it, and the stated range ends above it.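

In this assay the swap of ethyl for chloro gives a 1.2-fold lower number from compound 3 to compound 4 (0.07 log units; within the scatter). Set beside the earlier instance, the same change does not carry over at a fixed size between these two cores: the same change on two cores in this assay, a 5.5-fold higher number (0.74 log units; beyond the scatter) from compound 2 to compound 1 and a 1.2-fold lower number (0.07 log units; within the scatter) from compound 3 to compound 4, 6.6-fold (0.82 log units) apart, beyond the scatter of two such steps
This does not show what sets the gap, whether the place on the ring, here ortho to a large group and meta to a cyano group, or the rest of the core, and two pairs give no rule for other cores.

Open, from the compounds shown here alone, is whether ethyl and chloro at one same place on both cores would give matching steps. Also open, going by these compounds, is how a methoxy group or a longer chain would behave at these places.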